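Oxindole series: E to Z switch at compound 4

This account rests on a few compounds, and the source may have more. Where it says the series, first, only, none or still open, it means among the compounds named here.

Measured so far in a functional assay on BT-549 cells (Homo sapiens) for inhibition, read by MTT assay, with a stated time of 48 h; on this read-out higher numbers stand for weaker inhibition and lower numbers for stronger inhibition:
- compound 1 `COc1cc(Cn2cc(COc3cccc(/C=C4/C(=O)Nc5ccccc54)c3)nn2)cc(OC)c1`: "not determined" (no result reported)
- compound 2 `O=C1Nc2ccc(Cl)cc2/C1=C/c1cccc(OCc2cn(Cc3ccccc3)nn2)c1`: "not determined" (no result reported)
- compound 3 `O=C1Nc2ccc(C(c3ccccc3)c3ccccc3)cc2/C1=C\c1cccc(OCc2cn(Cc3ccccc3)nn2)c1`: > 50000 nM

Compound 3 stands at the limit of this assay, and the value > 50000 nM is a limit of the assay rather than a number (the limit of > 50000 nM in this assay, at which 1 of the 3 values shown sits). The two other compounds give no figure, so compound 3 is the only reference point in this assay.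

Compound 4 `O=C1Nc2ccc(C(c3ccccc3)c3ccccc3)cc2/C1=C/c1cccc(OCc2cn(Cc3ccccc3)nn2)c1` keeps every atom and bond of compound 3: the two compounds have the same atoms and bonds and differ only in configuration as drawn: 1 of 1 stereo elements differ; a double bond is drawn E in compound 3 and Z in compound 4. For the measured compounds named here, no measured step between two compounds with a number is available, so the size of the change cannot be read from data of this series. Because the reference sits at a limit (the limit of > 50000 nM in this assay, at which 1 of the 3 values shown sits), any number for compound 4 would already mean stronger inhibition. A step of an at least 2.5-fold lower number from compound 3 to compound 4 (0.39 log units; beyond the scatter) toward stronger inhibition is expected, with considerable uncertainty. For compound 4 in this assay the estimate is 20000 nM, spanning 3000 nM to 60000 nM.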

Compound 4, half-maximal inhibitory concentration: 15800 nM
Estimate against measurement, compound 4: 1.3-fold (0.10 log units) above, and the stated range covers the measured number.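

In this assay, configuration alone matters in this series: with atoms and bonds unchanged, the double bond drawn Z rather than E gives an at least 3.1-fold lower number from compound 3 to compound 4 (0.50 log units; beyond the scatter) and brings a measurable number into the series. The value for compound 3 is a limit, so the step has only a lower bound: the limit of > 50000 nM in this assay, at which 1 of the 4 values shown sits. The change can be assigned to the double bond and to nothing else: the fact that compounds 3 and 4 differ only in the configuration as drawn.

From the compounds shown here alone, it remains open whether the same switch carries over when an amine or a carboxylic acid stands in place of the diphenylmethyl group. Going by these compounds, the size of the full gap between the two configurations also remains open.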